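This account rests on a few compounds, and the source may have more. Where it says the series, first, only, none or still open, it means among the compounds named here.

Measured compounds:
compound 1, `Nc1nc(NCc2ccccc2F)nc(-c2ccccc2CO)n1`, 4.27;
compound 2, `Nc1nc(NCc2cccc(F)c2)nc(-c2ccccc2CO)n1`, 4.52.

In a functional assay on cells for positive allosteric modulation of G-protein coupled receptor 68 (Homo sapiens), read by a luciferase reporter and cAMP accumulation, with a stated time of 30 min, at pH 6.8 and pH 8.3, in the presence of a further agent that is not named here (a lower number here means a less potent compound, a higher number a more potent compound, by a factor of ten per unit of this negative logarithm), compound 1 `Nc1nc(NCc2ccccc2F)nc(-c2ccccc2CO)n1` gives 4.27. In this assay compound 2 `Nc1nc(NCc2cccc(F)c2)nc(-c2ccccc2CO)n1` gives 4.52. Compound 2 carries the higher of the two numbers, but the step of a number 0.25 log units higher from compound 1 to compound 2 (within the scatter) lies within the scatter, so the two compounds cannot be told apart on these data.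

Compound 3 `Nc1nc(NCc2ccc(F)cc2)nc(-c2ccccc2CO)n1` has not yet been measured. It differs from compound 2 by 4-fluorophenyl in place of 3-fluorophenyl on a saturated chain carbon bound to a nitrogen on an aromatic ring. Among the measured compounds shown here, the only measured step that bears on this change is the shift of the fluorine on the same ring between compound 1 and compound 2, a number 0.25 log units higher from compound 1 to compound 2 (within the scatter), and that step stayed within the scatter. For the measured compounds named here, the further shift to the 4-fluorophenyl is of the same kind and the same size, with only one precedent to draw on. For compound 3 no step beyond the scatter is therefore expected in this assay. The expected step is a number 0.02 log units lower from compound 2 to compound 3 (within the scatter). Compound 3 is estimated to give 4.5, within a range from 4.1 to 4.9.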

Compound 3, negative logarithm of the antagonist equilibrium constant: 3.97
Compound 3: the middle estimate sits 0.53 log units above what was measured, outside the stated range (below it).
By their numbers in this assay, from the lowest: compounds 3, 1 and 2 (each within the scatter of the next, the first and the last beyond it).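

In this assay this position proves sensitive to where the fluorine sits: on a saturated chain carbon bound to a nitrogen on an aromatic ring, 4-fluorophenyl in place of 3-fluorophenyl gives a number 0.55 log units lower from compound 2 to compound 3 (beyond the scatter), the only step among these three compounds that clears the scatter, and a modest one. With 4-fluorophenyl in place of 2-fluorophenyl the result is a number 0.30 log units lower from compound 1 to compound 3 (within the scatter), so compound 1 cannot be told apart from compound 3, just as it could not be told apart from compound 2, and the three fluorine placements separate only at the two ends of the series. Nothing given here bears on why 3-fluorobenzyl and 4-fluorobenzyl differ.

The compounds shown leave open whether this difference belongs to fluorine alone or would also appear with another group at the same places, such as chlorine or methoxy, and how any of the three compares with a plain, unsubstituted benzyl group. They also leave open whether the difference between 3-fluorobenzyl and 4-fluorobenzyl would persist if the hydroxymethyl group on the other phenyl ring gave way to a carboxylic acid or an amine.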